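Neopentyl for cyclopropylcarbonyl on the ring nitrogen

The source may report more compounds than this note shows. Statements on the series, on what has been measured and on what is new or still open speak of the compounds shown alone.

Compound 1 `O=C(c1cc2ccccc2[nH]1)N1CCC(NCCSC(c2ccc(F)cc2)c2ccc(F)cc2)CC1`: 1130 nM
Compound 2 `Fc1ccc(C(SCCNC2CCN(Cc3cc4ccccc4o3)CC2)c2ccc(F)cc2)cc1`: 205 nM
Compound 3 `O=C(C1CC1)N1CCC(NCCSC(c2ccc(F)cc2)c2ccc(F)cc2)CC1`: 46.4 nM

These three compounds share a core and differ only in the group on the amine nitrogen of the six-membered ring, measured in an assay on membranes from Cortex for displacement of a labelled ligand from Sigma non-opioid intracellular receptor 1 (Cavia porcellus), read by scintillation counting, with a stated time of 120 min; a lower number here means a stronger inhibitor, a higher number a weaker inhibitor. Compound 3 stands lowest of the three; the nearest is compound 2, with a 4.4-fold lower number from compound 2 to compound 3 (0.65 log units; beyond the scatter), and the furthest is compound 1, with a 24-fold lower number from compound 1 to compound 3 (1.39 log units; beyond the scatter).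

Compound 4 `CC(C)(C)CN1CCC(NCCSC(c2ccc(F)cc2)c2ccc(F)cc2)CC1` is not yet measured. It differs from compound 3 in one place: neopentyl in place of cyclopropylcarbonyl on an amine nitrogen in a ring. The step that bears most on this is a 5.5-fold lower number from compound 1 to compound 2 (0.74 log units; beyond the scatter), where a carbonyl-linked group on the same nitrogen gave way to a methylene-linked one and the number fell modestly. The other two steps, a 24-fold lower number from compound 1 to compound 3 (1.39 log units; beyond the scatter) and a 4.4-fold lower number from compound 2 to compound 3 (0.65 log units; beyond the scatter), show that a small group on this nitrogen gives a lower number than a large aromatic one. Since compound 4 keeps a small group and exchanges the carbonyl for a saturated chain, a modest step to a lower number is expected, a 2.3-fold lower number from compound 3 to compound 4 (0.37 log units; beyond the scatter). For compound 4 the estimate in this assay is 20 nM, with a range from 5 nM to 80 nM.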

Compound 4, inhibition constant: 315 nM
For compound 4 the middle estimate is 16-fold (1.20 log units) below the measured one; the measured number lies above the stated range.
By their numbers in this assay, from the lowest: compound 3; then compounds 2 and 4 (each within the scatter of the next); then compound 1.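

In this assay the exchange of cyclopropylcarbonyl for neopentyl, two groups with the same count of 5 heavy atoms, gives a 6.8-fold higher number from compound 3 to compound 4 (0.83 log units; beyond the scatter) and so shows that a small group on this ring nitrogen does not by itself bring the lowest number. The saturated chain also fails to keep any gain over the larger aromatic group on a methylene link, with a 1.5-fold higher number from compound 2 to compound 4 (0.19 log units; within the scatter) placing the two methylene-linked groups within the usual scatter of each other, while a 3.6-fold lower number from compound 1 to compound 4 (0.55 log units; beyond the scatter) leaves compound 4 lower only than the (1H-indol-2-yl)carbonyl compound. The type of link alone therefore does not order these compounds, since the carbonyl-linked compound 3 and compound 1 stand at opposite ends of the set.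

No measurement given here accounts for the higher number of compound 4. The change removes the carbonyl and the three-membered ring together, which leaves open which of them matters, and a cyclopropylmethyl group and a 2,2-dimethylpropanoyl group on the same nitrogen would separate the two.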